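The source may report more compounds than this note shows. Statements on the series, on what has been measured and on what is new or still open speak of the compounds shown alone.

Compound 3 `O=C1C=C(Nc2ccc(Br)cc2)C(=O)c2c1nc1n2[C@H]2OC[C@@H](O)[C@H]2OC1` holds the smallest of the three numbers in a functional assay on MGC-803 cells (Homo sapiens) for inhibition, read by sulforhodamine B assay (a lower number here means a stronger inhibitor, a higher number a weaker inhibitor), where compound 3 gives 1010 nM; compound 1 `O=C1C=C(Nc2ccc(I)cc2)C(=O)c2c1nc1n2[C@H]2OC[C@@H](O)[C@H]2OC1` gives 1400 nM, and compound 2 `CCOc1ccccc1NC1=CC(=O)c2nc3n(c2C1=O)[C@H]1OC[C@@H](O)[C@H]1OC3` gives 2450 nM. The step of a 1.4-fold lower number from compound 1 to compound 3 (0.14 log units; within the scatter) stays within the scatter, whereas a 2.4-fold lower number from compound 2 to compound 3 (0.38 log units; beyond the scatter) is a modest step beyond it. Compound 4 `O=C1C=C(Nc2ccccc2F)C(=O)c2c1nc1n2[C@H]2OC[C@@H](O)[C@H]2OC1` carries 2-fluorophenyl in place of 4-bromophenyl on an amine nitrogen. The step that bears on it is a 2.4-fold lower number from compound 2 to compound 3 (0.38 log units; beyond the scatter), in which the 2-ethoxyphenyl compound gave the higher number than the 4-bromophenyl compound; the halogen exchange a 1.4-fold lower number from compound 1 to compound 3 (0.14 log units; within the scatter) changed little. A modest shift toward a higher number is therefore expected for compound 4, about a 2.0-fold higher number from compound 3 to compound 4 (0.30 log units; within the scatter). Compound 4 is estimated at 2000 nM in this assay, with a range of 1000 nM to 4500 nM.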

Compound 4, half-maximal inhibitory concentration: 2080 nM
The estimate for compound 4 lay 1.0-fold (0.02 log units) below the measured number, within the range that was stated.
By their numbers in this assay, from the lowest: compounds 3, 1, 4 and 2 (each within the scatter of the next, the first and the last beyond it).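

Replacing 4-bromophenyl with 2-fluorophenyl on the amine nitrogen gives a 2.1-fold higher number from compound 3 to compound 4 (0.31 log units; beyond the scatter), a second modest step away from compound 3 in this assay. Fluoro in place of ethoxy gives a 1.2-fold lower number from compound 2 to compound 4 (0.07 log units; within the scatter), so the 2-fluorophenyl and 2-ethoxyphenyl groups cannot be told apart here, and a 1.5-fold higher number from compound 1 to compound 4 (0.17 log units; within the scatter) likewise separates compound 4 from the 4-iodophenyl compound by no more than the scatter. Nothing at hand accounts for these steps.

Open, from the compounds shown here alone, is how the unsubstituted phenyl or 4-fluorophenyl group would read, which would separate the halogen from its place on the ring. Also open, going by these compounds, is how a phenyl carrying a carboxylic acid or an amine would read.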